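Halogen swap on a triazole aryl in an inactive pair

This account rests on a few compounds, and the source may have more. Where it says the series, first, only, none or still open, it means among the compounds named here.

Measured so far in a functional assay on HepG2 cells (Homo sapiens) for antiproliferative activity, read by MTT assay, with a stated time of 48 h; a lower number here means a stronger inhibitor, a higher number a weaker inhibitor:
- compound 1, `N#CC1=C(N)Oc2c(c3nc4ccccc4nc3c3ccccc23)C12C(=O)N(Cc1cnnn1-c1ccccc1Cl)c1ccccc12`: compound 1 gives > 50000 nM, a limit of the assay.
- compound 2, `N#CC1=C(N)Oc2c(N)cc3nc4ccccc4nc3c2C12C(=O)N(Cc1cnnn1-c1ccc(F)cc1)c1ccccc12`: compound 2 gives > 50000 nM, a limit of the assay.

Compound 2 therefore stands at the limit of this assay and not at a number. Both values shown sit at the limit of > 50000 nM in this assay, at which 2 of the 2 values shown sit, so no measured step between compounds exists and nothing about the shared core has yet shown activity within the range of the assay.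

Compound 3, `N#CC1=C(N)Oc2c(N)cc3nc4ccccc4nc3c2C12C(=O)N(Cc1cnnn1-c1cccc(Br)c1)c1ccccc12`, differs from compound 2 in one place: 3-bromophenyl in place of 4-fluorophenyl on an aromatic nitrogen. Within the data shown here, with no measured step to lean on, the expected change from compound 2 to compound 3 is none beyond the scatter, namely a number no higher from compound 2 to compound 3 (the limit leaves the size open). Compound 3 is accordingly estimated at 50000 nM, within 15000 nM to 200000 nM, and most likely again only a limit will be reported.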

Compound 3, half-maximal inhibitory concentration: > 50000 nM
Compound 3: a limit, no number (the forecaster's own chance of this, stated with the estimate: 75%); the middle value lies on the limit itself.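

In this assay compound 3 gives > 50000 nM as a limit of the assay, and compound 2 also stands at a limit, so no step can be read between them. The compounds shown leave open whether any change to the triazole aryl group or the shared core brings a value within the assay's range: the limit of > 50000 nM in this assay, at which 3 of the 3 values shown sit.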